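Swapping ethyl for 3-methylphenyl on compound 1

The compounds below may be only part of what the source reports. "The series", "measured", "known", "first", "only" and "open" are said of these compounds alone.

Compound 1 `CCCn1c(N)c(C#N)c2c(N)ncnc21` gives 15000 nM
Compound 2 `CCOCn1c(N)c(C(N)=O)c2c(N)ncnc21` gives > 100000 nM as a limit of the assay and not a number

Among the measured compounds shown here, in a functional assay on KB cells (Homo sapiens) for inhibition (a lower number here means a stronger inhibitor, a higher number a weaker inhibitor), compound 1 holds the only true number so far, 15000 nM in a set of two results. The other result, for compound 2, is a limit.

Compound 3 `Cc1cccc(Cn2c(N)c(C#N)c3c(N)ncnc32)c1` has not yet been measured. It keeps the shared core and the nitrile of compound 1 and differs from it in one place: 3-methylphenyl in place of ethyl on a saturated chain carbon bound to an aromatic nitrogen on a saturated chain carbon bound to an aromatic nitrogen. A small ethyl end thus gives way to a six-membered aromatic ring of carbon only.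

For the measured compounds named here, no measured pair of compounds shows what this kind of swap does, so the margin must stay wide. No step beyond the usual scatter is expected in this assay and the expected change is a 1.5-fold lower number from compound 1 to compound 3 (0.18 log units; within the scatter) on this estimate. For compound 3 the estimated value is 10000 nM with an expected range of 2000 nM to 50000 nM in this read-out.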

Compound 3, half-maximal inhibitory concentration: > 100000 nM
Compound 3: only a limit was reported (the forecaster's own chance of this, stated with the estimate: 20%); middle value at least 10-fold (1.00 log units) away from the limit.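

In this assay, the saturated chain carbon bound to an aromatic nitrogen proves sensitive to what it carries: with the nitrile kept, 3-methylphenyl in place of ethyl gives an at least 6.6-fold higher number from compound 1 to compound 3 (0.82 log units; beyond the scatter). Compound 2 could not show this, since it differs from compound 1 in more than one place. Compound 3 gives > 100000 nM, which is a limit of the assay and not a number, and the step can be read only as a minimum because of that limit: the limit of > 100000 nM in this assay, at which 2 of the 3 values shown sit.

On these data alone, whether the loss belongs to the aromatic ring or to its methyl stays open, and a plain phenyl would separate the two. As far as these compounds go, it is also open whether a longer chain such as butyl, or a chain ending in an amine, would hold the level of compound 1 or improve on it.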